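The compounds below may be only part of what the source reports. "The series", "measured", "known", "first", "only" and "open" are said of these compounds alone.

Working notes on the series in a functional assay on MGC-803 cells (Homo sapiens) for antiproliferative activity, read by CellTiter-Glo, with a stated time of 72 h; a higher number here means a weaker inhibitor, a lower number a stronger inhibitor. Of the compounds shown here, three on a shared core have been measured: compound 1 `O=C(NO)c1ccc(/C=C/c2ccnc(-c3cc(F)ccc3O)c2)cc1` gives 1920 nM, compound 2 `O=C(NO)c1ccc(/C=C/c2ccnc(-c3ccccc3O)c2)cc1` gives 1420 nM, and compound 3 `O=C(NO)c1ccc(/C=C/c2ccnc(-c3cccc(CO)c3)c2)cc1` gives 1740 nM. These numbers all lie within the scatter of one another, so compound 3 stands level with the other two.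

The next entry is compound 4 `O=C(NO)c1ccc(/C=C/c2ccnc(-c3cccnc3)c2)cc1`, with pyridin-3-yl in place of 3-(hydroxymethyl)phenyl on an aromatic carbon.

Two measured steps exchange the whole group at this place: a 1.1-fold lower number from compound 1 to compound 3 (0.04 log units; within the scatter) and a 1.2-fold higher number from compound 2 to compound 3 (0.09 log units; within the scatter). A third step, a 1.4-fold lower number from compound 1 to compound 2 (0.13 log units; within the scatter), has hydrogen in place of fluoro on that group. All three stay within the scatter. Within the data shown here, none of the measured compounds has a ring nitrogen in this group, so the data offer no direct precedent for the change, and no direction can be assigned to it. In this assay, no step beyond the scatter is therefore expected, though the range is kept wide. The estimated step is a 1.1-fold lower number from compound 3 to compound 4 (0.04 log units; within the scatter). Compound 4 is estimated at 1600 nM, with an expected range of 700 nM to 3500 nM.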

Compound 4, half-maximal inhibitory concentration: 4550 nM
The estimate for compound 4 lay 2.8-fold (0.45 log units) below the measured number, and the stated range ends below it.
By their numbers in this assay, from the lowest: compounds 2, 3 and 1 (each within the scatter of the next); then compound 4.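

In this assay, among these compounds, pyridin-3-yl is the first group at this place, on the aromatic carbon next to the ring nitrogen, to give a step beyond the scatter: the change gives a 2.6-fold higher number from compound 3 to compound 4 (0.42 log units; beyond the scatter) and, against the two hydroxyphenyl groups, a 3.2-fold higher number from compound 2 to compound 4 (0.51 log units; beyond the scatter) and a 2.4-fold higher number from compound 1 to compound 4 (0.37 log units; beyond the scatter). The place is therefore not indifferent to the group it carries, even though 3-(hydroxymethyl)phenyl, 2-hydroxyphenyl and 5-fluoro-2-hydroxyphenyl stand level with one another, and all three steps are modest in size. No measured evidence bears on the origin of this loss.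

Compared with compound 3, compound 4 has a ring nitrogen, no hydrogen-bond donor and fewer heavy atoms, and these differences change together, so the compounds shown cannot assign the step to any one of them. Plain phenyl, pyridin-3-yl carrying a hydroxymethyl group, and 3-aminophenyl would separate the ring nitrogen from the loss of the hydroxyl group, and the other pyridine isomers remain open as well.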